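From compound 1 to its methyl counterpart, compound 3

The source may hold more compounds than are shown below. What is called first, only, known or untested is meant among the compounds shown, and "the series" means these compounds.

For the measured compounds named here, in a functional assay on Huh-5-2 cells (Homo sapiens) for cytotoxicity, read by microscopy (on this read-out higher numbers stand for lower toxicity in this test and lower numbers for higher toxicity in this test), compound 1 `CC(=O)OC[C@H]1O[C@@H](n2c(SCc3cc4ccccc4oc3=O)nc3cncnc32)[C@H](OC(C)=O)[C@@H]1OC(C)=O` gives 39000 nM, the higher of the two numbers measured so far. Going by the values given here, the only measured comparison is compound 2 `CC(=O)OC[C@H]1O[C@@H](n2c(SCc3cc4cc(Br)ccc4oc3=O)nc3cncnc32)[C@H](OC(C)=O)[C@@H]1OC(C)=O`, which gives 6700 nM in this assay. These two compounds differ by bromo in place of hydrogen on an aromatic carbon, and the numbers show a 5.8-fold lower number from compound 1 to compound 2 (0.76 log units; beyond the scatter). Compound 3 `CC(=O)OC[C@H]1O[C@@H](n2c(SCc3cc4cc(C)ccc4oc3=O)nc3cncnc32)[C@H](OC(C)=O)[C@@H]1OC(C)=O` has not yet been measured. Its difference from compound 1 is this: methyl in place of hydrogen on an aromatic carbon. In words, it is methyl in place of hydrogen on an aromatic carbon, a change of the same kind as in compound 2, with methyl entering instead of bromo. That single step is the only one that bears on this change, and one step establishes no trend. Resting on the step from bromo, a 5.8-fold lower number from compound 1 to compound 2 (0.76 log units; beyond the scatter), a lower number in this assay is expected, but a smaller step is expected for methyl. The estimated step is a 2.2-fold lower number from compound 1 to compound 3 (0.34 log units; beyond the scatter). For compound 3 the expected value is 18000 nM, with an estimated range of 7000 nM to 45000 nM.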

Compound 3, half-maximal cytotoxic concentration: 16000 nM
For compound 3 the middle estimate is 1.1-fold (0.05 log units) above the measured one; measured number inside the range.
By their numbers in this assay, from the lowest: compound 2; then compound 3; then compound 1.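

In this assay, the aromatic carbon that is meta to a fused ring and para to a fused ring has now taken two different groups in place of hydrogen, and both lower the number. Methyl, which enters with a single carbon, gives a step of its own beyond the scatter (a 2.4-fold lower number from compound 1 to compound 3 (0.39 log units; beyond the scatter)), so this effect on the read-out is not confined to bromo. The identity of the group also matters, since exchanging bromo for methyl at the same place raises the number (a 2.4-fold higher number from compound 2 to compound 3 (0.38 log units; beyond the scatter)), leaving compound 3 between compound 2 and compound 1 in this series, and no independent measurement accounts for this difference between the groups.

The compounds shown leave open whether this ordering extends to other groups at this place, such as an amine, a carboxylic acid, a methoxy group or a longer chain like ethyl. They also leave open whether methyl or bromo would change the number in the same way on another carbon of this ring.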